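A few compounds are considered here, and "the series" means these few. Any claim that something is new, unique, unknown or untested is made for them only; others in the source may bear on it.

The read-out throughout is an ADME assay on cells (Fibroblast, Homo sapiens) for cytotoxicity, with a stated time of 48 h; on this read-out lower numbers stand for stronger inhibition and higher numbers for weaker inhibition. Compound 1 `O=[N+]([O-])c1ccc(CN2CCC(n3cc(CC(OCc4cc(-c5ccc(Br)cc5)no4)c4ccc(Br)cc4)nn3)CC2)cc1` gives in this assay > 25000 nM, which is a limit of the assay and not a number. Compound 2 `N#Cc1cccc(-c2cc(COC(Cc3cn(C4CCN(Cc5ccc([N+](=O)[O-])cc5)CC4)nn3)c3ccc(Br)cc3)on2)c1`, which carries a 3-cyanophenyl in place of the 4-bromophenyl on an aromatic carbon, gives in this assay > 25000 nM, again a limit rather than a number. The step that the two limits leave unreadable from compound 1 to compound 2 thus has no readable size. Where compound 2 stands can be told only as far as the limit of > 25000 nM in this assay, at which 2 of the 2 values shown sit, allows: it sits at that limit, as does the one further value shown.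

Compound 3 `O=[N+]([O-])c1ccc(CN2CCC(n3cc(CC(OCc4cc(-c5ccccc5F)no4)c4ccc(Br)cc4)nn3)CC2)cc1` has not yet been measured. It differs from compound 2 by 2-fluorophenyl in place of 3-cyanophenyl on an aromatic carbon. Among the measured compounds shown here, the sole measured step, from compound 1 to compound 2, is the only one that bears on this change, and it is unreadable, so no size or direction can be drawn from it. It is therefore expected that compound 3 will again sit at the limit, the step that the limit leaves unreadable from compound 2 to compound 3 being no change beyond the scatter. The estimate for compound 3 is 30000 nM, in the range 12000 nM to 80000 nM.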

Compound 3, half-maximal inhibitory concentration: > 25000 nM
Compound 3: no number, only a limit; the forecaster's own chance of this, stated with the estimate: 85%; the middle value is on the limit's open side.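

Compound 3, like compound 1 and compound 2, gives only a limit and not a number, so no step among these compounds can be read in this assay: the limit of > 25000 nM in this assay, at which 3 of the 3 values shown sit. The compounds shown leave open where each true value lies and whether 4-bromophenyl, 3-cyanophenyl and 2-fluorophenyl differ at all in this assay.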